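Flipping One Stereocentre in a Sulfonamide Series

The source may hold more compounds than are shown below. What is called first, only, known or untested is meant among the compounds shown, and "the series" means these compounds.

The measured compounds and their values in an assay on cells for inhibition of cytochrome P450 11B2, mitochondrial (Homo sapiens); on this read-out higher numbers stand for weaker inhibition and lower numbers for stronger inhibition:
compound 1, `C[C@@H](c1ccc(Cl)cc1)N1Cc2cncn2C(CC2(C)COC2)S1(=O)=O`, gives 7.8 nM
compound 2, `CC(C)CC1n2cncc2CN(Cc2ccccc2)S1(=O)=O`, gives 18.6 nM
compound 3, `CC(C)CC1n2cncc2CN([C@H](C)c2ccc(Cl)cc2)S1(=O)=O`, gives 61.7 nM

Among these three, compound 3 stands at the highest number, that is, it is the weakest inhibitor of the group. Its nearest neighbour is compound 2, whose number is lower by a margin beyond the usual scatter of this assay, and compound 1 lies further still, with a much lower number.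

The step considered here leads from compound 3 to compound 4, `CC(C)CC1n2cncc2CN([C@@H](C)c2ccc(Cl)cc2)S1(=O)=O`. The two compounds have the same atoms and bonds; at least one stereo element is drawn with a configuration in one of them and without one in the other: 1 of 2 stereo elements differ; a stereocentre at a saturated chain carbon is drawn R in compound 3 and S in compound 4 (the two compounds have the same atoms and bonds; at least one stereo element is drawn with a configuration in one of them and without one in the other: 1 of 2 stereo elements differ; a stereocentre at a saturated chain carbon is drawn R in compound 3 and S in compound 4). Within the data shown here, in plain terms, compound 4 is the mirror-image form of compound 3 at that one carbon, the one carrying the methyl group and the chlorophenyl ring.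

Among the measured compounds shown here, no measured pair in this set differs only in this stereocentre, so the size of the step cannot be read off directly. Still, compound 1 carries the same S configuration at that chain carbon and gives 7.8 nM, although it also differs from compound 4 elsewhere. Because compound 1 gives 7.8 nM with this configuration, a change toward a lower number is expected for compound 4, larger than the scatter. The expected step from compound 3 to compound 4 is a 5.1-fold lower number from compound 3 to compound 4 (0.71 log units; beyond the scatter). The estimate for compound 4 in this assay is 12 nM, with a range from 3 nM to 50 nM.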

Compound 4, half-maximal inhibitory concentration: 9.4 nM
Compound 4: middle estimate off by 1.3-fold (0.11 log units), on the high side; the range from low to high includes it.
By their numbers in this assay, from the lowest: compounds 1, 4 and 2 (each within the scatter of the next, the first and the last beyond it); then compound 3.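

In this assay, among these compounds, the configuration at the chain carbon carrying the methyl group and the chlorophenyl ring proves to matter on its own: with atoms and bonds unchanged, the step is a 6.6-fold lower number from compound 3 to compound 4 (0.82 log units; beyond the scatter), a comparison the earlier compounds could not offer, since none of them differed in this stereocentre alone. With the S configuration held fixed, the other side of the molecule looks tolerant in this pair, as isopropyl in place of 3-methyloxetan-3-yl on the saturated chain carbon gives a 1.2-fold higher number from compound 1 to compound 4 (0.08 log units; within the scatter). This reading of the stereocentre rests on how the two structures are drawn: the fact that one of compounds 3 and 4 is drawn with a defined configuration and the other without, at the place where they differ.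

The compounds shown leave open whether the S form keeps its advantage when the 3-methyloxetan-3-yl group takes the place of isopropyl, and what the configuration at the saturated ring carbon contributes. They also cannot tell whether the preference survives if an ethyl group replaces the methyl on the stereocentre, or if a pyridine ring replaces the chlorophenyl ring.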